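The source may report more compounds than this note shows. Statements on the series, on what has been measured and on what is new or still open speak of the compounds shown alone.

Three amides share the core of compound 1 `CCn1c(C(=O)NCCN(C)C)ccc1C(CC)(CC)c1ccc(OCCC(O)(CC)CC)c(C)c1` and differ only in the group on the amide-type nitrogen. Among the measured compounds shown here, in a functional assay on PC-3 cells (Homo sapiens) for antiproliferative activity, read by MTT assay, with a stated time of 48 h (on this read-out higher numbers stand for weaker inhibition and lower numbers for stronger inhibition), compound 1 gives 870 nM, while compound 2 `CCC(C)C(CO)NC(=O)c1ccc(C(CC)(CC)c2ccc(OCCC(O)(CC)CC)c(C)c2)n1CC` gives 28400 nM, the higher of the two numbers so far. Compound 3 `CCn1c(C(=O)NC(CO)CCO)ccc1C(CC)(CC)c1ccc(OCCC(O)(CC)CC)c(C)c1` departs from compound 2 on a saturated chain carbon bound to an amide-type nitrogen and a saturated chain carbon: 2-hydroxyethyl in place of sec-butyl on a saturated chain carbon bound to an amide-type nitrogen and a saturated chain carbon. For the measured compounds named here, the only measured step, a 33-fold higher number from compound 1 to compound 2 (1.51 log units; beyond the scatter), is large, but it exchanges 2-(dimethylamino)ethyl for 1-(hydroxymethyl)-2-methylbutyl, and that is a different change. Compound 3 does not restore the 2-(dimethylamino)ethyl group, so no measured step sizes this swap directly, and no step beyond the scatter is expected in this assay. The expected change is a 1.4-fold lower number from compound 2 to compound 3 (0.15 log units; within the scatter). For compound 3 the estimated value is 20000 nM, with an expected range of 6000 nM to 60000 nM.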

Compound 3, half-maximal inhibitory concentration: 8760 nM
Beside the measured number, compound 3's estimate is 2.3-fold (0.36 log units) above it; measured number inside the range.
By their numbers in this assay, from the lowest: compound 1; then compound 3; then compound 2.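

In this assay, the saturated chain carbon bound to an amide-type nitrogen and a saturated chain carbon proves sensitive to its substituent: with 2-hydroxyethyl in place of sec-butyl, the read-out shows a 3.2-fold lower number from compound 2 to compound 3 (0.51 log units; beyond the scatter), a step beyond the scatter. The 3-hydroxy-1-(hydroxymethyl)propyl group still does not match the 2-(dimethylamino)ethyl group on the amide-type nitrogen, as the read-out shows a 10-fold higher number from compound 1 to compound 3 (1.00 log units; beyond the scatter), so the lower number of compound 3 recovers only part of the difference. No available evidence accounts for either step.

From the compounds shown here alone, it remains open whether the shift at this carbon depends on the hydroxyl group or on the loss of sec-butyl, a question that an ethyl chain or a longer hydroxyalkyl chain could address. Going by these compounds, whether a dimethylamino group on the branched chain of compound 3 would bring the number closer to that of compound 1 also remains open.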